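Methoxy for chloro in a low-cytotoxicity urea series

The source may report more compounds than this note shows. Statements on the series, on what has been measured and on what is new or still open speak of the compounds shown alone.

Measured so far in an ADME assay on BJ cells (Homo sapiens) for cytotoxicity, with a stated time of 72 h; a lower number here means that less compound is needed, a higher number that more compound is needed for the effect:
compound 1 `Cc1cc(NC(=O)Nc2ccc(C)c(Cl)c2)c2ccccc2n1`: > 25000 nM (a limit of the assay)
compound 2 `Cc1cc(NC(=O)Nc2ccc(Cl)c(Cl)c2)c2ccccc2n1`: 23000 nM (a number)
compound 3 `Cc1cc(NC(=O)Nc2ccc(F)c(F)c2)c2ccccc2n1`: > 25000 nM (a limit of the assay)

Within the data shown here, compound 2 stands alone as the only compound with an actual number (23000 nM) . The other two results are limits. The set is therefore defined mainly by the limit of > 25000 nM in this assay, at which 2 of the 3 values shown sit, and it offers little to calibrate any step.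

The next compound is compound 4 `COc1ccc(NC(=O)Nc2cc(C)nc3ccccc23)cc1Cl`, which has not yet been measured. Its difference from compound 2 is methoxy in place of chloro on an aromatic carbon, ortho to a chloro group and para to a large group.

Among the measured compounds shown here, one measured step bears on this place: an at least 1.0-fold lower number from compound 1 to compound 2 (0.03 log units; that floor lies within the scatter), for chloro in place of methyl. That step rests on a limit and shows no change beyond the scatter. No step beyond the scatter is therefore expected in this assay, and a result reported only as a limit would not be surprising. The expected change is a 1.0-fold higher number from compound 2 to compound 4 (0.02 log units; within the scatter), with no clear direction. For compound 4 the estimated value is 24000 nM, with an expected range from 12000 nM to 30000 nM.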

Compound 4, half-maximal effective concentration: 23000 nM
Compound 4: the middle estimate sits 1.0-fold (0.02 log units) above what was measured, within the range that was stated.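

In this assay, among these compounds, methoxy in place of chloro on the aromatic carbon ortho to a chloro group and para to a large group gives no change at the digits printed from compound 2 to compound 4 (within the scatter), the first step at this position with a number at both ends. Compound 1 gives > 25000 nM, which is a limit of the assay. Among the compounds shown here, the step for methoxy in place of methyl therefore reads only as an at least 1.0-fold lower number from compound 1 to compound 4 (0.03 log units; that floor lies within the scatter), and it fixes no size for that change, so the exchange of chloro for methoxy is the only firm reading at this position and it shows no change beyond the scatter.

As far as these compounds go, whether any group at this position moves the number beyond the scatter stays open, and the room for reading such a move is narrow: the limit of > 25000 nM in this assay, at which 2 of the 4 values shown sit. An amine, a carboxylic acid or a longer chain in place of the methoxy would test whether the tolerance seen with chloro and methoxy extends to groups of a different kind.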